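A few compounds are considered here, and "the series" means these few. Any claim that something is new, unique, unknown or untested is made for them only; others in the source may bear on it.

Working notes on the series. Compound 1 `Cn1cncc1C(OCc1ccc(C#N)cc1-c1cccc2ccccc12)c1ccc(C#N)nc1` carries a naphthalen-1-yl group on its core; in an assay on isolated protein (Bos taurus) for inhibition of geranylgeranyl transferase type-1 subunit beta (Homo sapiens) (on this read-out lower numbers stand for stronger inhibition and higher numbers for weaker inhibition), compound 1 gives > 10 nM, which is a limit of this assay and not a number, so it sits at the limit of > 10 nM in this assay, at which 1 of the 3 values shown sits. Compound 2 `Cn1cncc1C(OCc1ccc(C#N)nc1N1CCN(C(=O)OC(C)(C)C)CC1)c1ccc(C#N)cc1` gives 42 nM in this assay. Compound 3 `Cn1cncc1C(OCc1ccc(C#N)nc1-c1cc(Cl)cc(Cl)c1)c1ccc(C#N)cc1`, which also bears a 3,5-dichlorophenyl group, gives 1400 nM in this assay. Compound 4 `Cn1cncc1C(OCc1ccc(C#N)cc1-c1cc(Cl)cc(Cl)c1)c1ccc(C#N)nc1` arises from compound 1 by 3,5-dichlorophenyl in place of naphthalen-1-yl on an aromatic carbon. For the measured compounds named here, no measured pair in the set covers this change, so its size is open; the value of compound 3 leaves room for a weak result. For compound 4 the expected step is a step that the limit leaves unreadable from compound 1 to compound 4, and compound 4 is estimated at 300 nM in this assay, within 60 nM to 2000 nM.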

Compound 4, half-maximal inhibitory concentration: 960 nM
Compound 4: the middle estimate sits 3.2-fold (0.51 log units) below what was measured; low and high end bracket the measured number.
By their numbers in this assay, from the lowest: compound 2; then compounds 4 and 3 (each within the scatter of the next).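

For the compounds shown here, compound 1 gives > 10 nM in this assay, which is a limit and not a number, so no step from compound 1 to compound 4 can be read. The compounds shown leave open whether naphthalen-1-yl or 3,5-dichlorophenyl gives the stronger inhibition on this core.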